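Trimming an Ethyl to a Methyl on the Pyrazole

The source may report more compounds than this note shows. Statements on the series, on what has been measured and on what is new or still open speak of the compounds shown alone.

Compound 1 `CCc1n[nH]cc1-c1cc2c(s1)C(=O)NC(C)(C)N2C` was tested in an assay for inhibition of Rho-associated protein kinase 1 (Homo sapiens), read by TR-FRET, with stated times of 5 min and 2 h (on this read-out lower numbers stand for stronger inhibition and higher numbers for weaker inhibition), where compound 1 gave 350 nM. For the measured compounds named here, of the two compounds measured so far it holds the higher number; compound 2 `CC(C)C1(C)NC(=O)c2sc(-c3ccncc3)cc2N1` gives 35 nM in this assay, a lower number by a margin beyond the usual scatter. Going by the values given here, no pair of measured compounds differs in just one place, so no single measured step is available to guide the next change.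

Compound 3 `Cc1n[nH]cc1-c1cc2c(s1)C(=O)NC(C)(C)N2C` is the unmeasured compound. It differs from compound 1 by hydrogen in place of methyl on a saturated chain carbon bound to an aromatic carbon; cut one bond further out, the change reads ethyl to methyl. Such a short trim of a chain gives no ground to expect a large shift. The step from compound 1 to compound 3 is expected to be no change at the digits printed from compound 1 to compound 3 (within the scatter), in neither direction beyond the scatter. Compound 3 is therefore estimated at 350 nM, within a range from 120 nM to 1000 nM.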

Compound 3, half-maximal inhibitory concentration: 54 nM
Estimate against measurement, compound 3: 6.5-fold (0.81 log units) above, and the stated range ends above it.
By their numbers in this assay, from the lowest: compounds 2 and 3 (each within the scatter of the next); then compound 1.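

Trimming ethyl to methyl gives a 6.5-fold lower number from compound 1 to compound 3 (0.81 log units; beyond the scatter) in this assay, so removing a single carbon at this place on the chain is enough to move the number beyond the usual scatter. For the compounds shown here, this is the first measured change made in one place only, and it shows that the read-out responds to the length of this small chain. Nothing measured here explains the shift.

The compounds shown leave open how a longer chain such as propyl, a branched group such as isopropyl, or an amine would read at this place. Going by these compounds alone, with only one pair, it also remains open whether the same trim would give a step of similar size on a different core.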